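Shortening the amine tail in a thiazole antagonist series

This account rests on a few compounds, and the source may have more. Where it says the series, first, only, none or still open, it means among the compounds named here.

The compounds measured so far, with their values in an assay on isolated protein for antagonist activity at advanced glycosylation end product-specific receptor (Homo sapiens), read by ELISA, with a stated time of 60 min, tested at 10 uM; a higher number here means more inhibition at the concentration tested (going by the name of the read-out), a lower number less inhibition:

compound 1, `CCCCc1sc(-c2ccc(OCC3CCCN(CC)C3)cc2)nc1-c1ccc(Oc2ccc(Cl)cc2)cc1`, 58%
compound 2, `CCCCc1sc(-c2ccc(Oc3ccc(Cl)cc3)cc2)nc1-c1ccc(OCC2CCCN(CC)C2)cc1`, 55.9%
compound 3, `CCCCc1sc(-c2ccc(OCCCN3CCCCC3)cc2)nc1-c1ccc(Oc2ccc(Cl)cc2)cc1`, 59.2%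

Compound 3 carries the highest number of the three, but its lead over compound 1 is within the scatter, and so is the gap to compound 2; on these numbers the inhibition of the three is level. Within the data shown here, the one step that bears on the new compound is the exchange of the amine-bearing tail from compound 1 to compound 3, which gave a number 1.2 percentage points higher from compound 1 to compound 3 (within the scatter), a shift of no consequence.

Compound 4, `CCCCc1sc(-c2ccc(OCCCN(C)C)cc2)nc1-c1ccc(Oc2ccc(Cl)cc2)cc1`, differs from compound 3 in that tail only: dimethylamino in place of piperidin-1-yl on a saturated chain carbon, three bonds along the chain from an oxygen on an aromatic ring. Among the measured compounds shown here, since the only comparable change, from compound 1 to compound 3, left the inhibition within the scatter, there is nothing in the data to suggest that this further trimming of the amine will move the number either way. The expectation for compound 4 is therefore a value close to that of compound 3, and the expected step of a number 2.2 percentage points lower from compound 3 to compound 4 (within the scatter) is a small one that stays within the scatter. The estimate for compound 4 in this assay is 57%, with a range from 45% to 68%.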

Compound 4, a percentage reported as inhibition, at one concentration (the size of the read-out at that concentration, not a potency): 46.2%
The estimate for compound 4 lay 10.8 percentage points above the measured number; measured number inside the range.
By their numbers in this assay, from the lowest: compounds 4, 2, 1 and 3 (each within the scatter of the next, the first and the last beyond it).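

In this assay the tail turns out not to be indifferent: dimethylamino in place of piperidin-1-yl, on a saturated chain carbon, three bonds along the chain from an oxygen on an aromatic ring, gave a number 13 percentage points lower from compound 3 to compound 4 (beyond the scatter) and thus a step of real size at this position. Measured against the other ring-bearing tail, the change to 2-(dimethylamino)ethyl gave a number 11.8 percentage points lower from compound 1 to compound 4 (beyond the scatter) in the same direction, whereas the exchange between the two tails that both hold a ring gave only a number 1.2 percentage points higher from compound 1 to compound 3 (within the scatter) and so left them level. Nothing measured here gives an explanation for the lower number of the ring-free tail.

The compounds shown leave open whether the ring itself or the number of heavy atoms on the amine matters, since the two change together between piperidin-1-yl and dimethylamino. Going by these compounds, a diethylamino group or a pyrrolidin-1-yl ring on the same chain would begin to separate the two, and it remains open whether the same exchange would have a similar effect with the two aryl groups swapped, as in compound 2.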